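Series notes: aryl exchange on the shared core, compound 4

The compounds below may be only part of what the source reports. "The series", "measured", "known", "first", "only" and "open" are said of these compounds alone.

Measured so far, in a functional assay on NCI/ADR-RES cells (Homo sapiens) for inhibition; on this read-out lower numbers stand for stronger inhibition of growth and higher numbers for weaker inhibition of growth:
- compound 1 `COc1cc(/C=C/C(=O)c2cccc(-n3cc(-c4ccc(Cl)cc4)[nH]c3=O)c2)cc(OC)c1OC`: 2360 nM
- compound 2 `COc1cc(/C=C/C(=O)c2cccc(-n3cc(-c4ccccc4)[nH]c3=O)c2)ccc1O`: 2920 nM
- compound 3 `COc1ccc(-c2cn(-c3cccc(C(=O)/C=C/c4ccc(O)c(OC)c4)c3)c(=O)[nH]2)cc1`: 2560 nM

Compound 1 shows the lowest of the three numbers, but its gap to compound 3 and its gap to compound 2 are both within the scatter, so the three measured compounds are not separated in this assay. Among the measured compounds shown here, the only single-point step in hand is a 1.1-fold lower number from compound 2 to compound 3 (0.06 log units; within the scatter), a methoxy added on the aryl group carried by the core, and it changes nothing beyond the scatter.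

Compound 4 `COc1cc(/C=C/C(=O)c2cccc(-n3cc(-c4cc(OC)c(OC)c(OC)c4)[nH]c3=O)c2)cc(OC)c1OC` differs from compound 1 by 3,4,5-trimethoxyphenyl in place of 4-chlorophenyl on an aromatic carbon. For the measured compounds named here, no measured step covers this exchange. The closest comparison is the change from compound 2 to compound 3, a 1.1-fold lower number from compound 2 to compound 3 (0.06 log units; within the scatter), which touches the same aryl group and stayed within the scatter; the three measured compounds, which differ in their substitution on that aryl group, also sit within the scatter of one another. Nothing in hand therefore points to a step beyond the scatter in this assay in either direction. Compound 4 is expected to give 2500 nM, with a range from 1000 nM to 6500 nM. The expected step is a 1.1-fold higher number from compound 1 to compound 4 (0.03 log units; within the scatter), within the scatter.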

Compound 4, concentration for 50% growth inhibition: 2100 nM
Estimate against measurement, compound 4: 1.2-fold (0.08 log units) above; the measured number falls inside the stated range.
By their numbers in this assay, from the lowest: compounds 4, 1, 3 and 2 (each within the scatter of the next).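

In this assay, the exchange at this position, on an aromatic carbon of the five-membered ring next to the ring nitrogen, gives a 1.1-fold lower number from compound 1 to compound 4 (0.05 log units; within the scatter). The earlier step on this aryl group, a 1.1-fold lower number from compound 2 to compound 3 (0.06 log units; within the scatter), added a single methoxy, whereas this one replaces the whole 4-chlorophenyl group: the chlorine leaves, the entering 3,4,5-trimethoxyphenyl group has more heavy atoms, and the hydrogen-bond acceptors on the substituent go from 0 to 3, yet the step still stays within the scatter, so this position tolerates a far larger exchange than the earlier step could show, with no separation in this read-out. No measurement at hand offers an explanation for the absence of a separation, and no reason for it can be given here.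

The aryl groups shown all carry neutral substituents, so it remains open whether an amine or a carboxylic acid on this aryl group would give a step beyond the scatter. Also open, on these data alone, is whether replacing the aryl group with a longer chain of carbon atoms would leave the number within the scatter of compound 1.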